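The compounds below may be only part of what the source reports. "The series", "measured", "known", "first", "only" and "open" are said of these compounds alone.

Compound 1 `CN(C)/C=N/c1c(C=O)c(-c2ccccc2)nn1-c1ccccc1` and compound 2 `Cc1ccc(-c2nn(-c3cccc(Cl)c3)c(/N=C/N(C)C)c2C=O)cc1` share a core whose difference between the two is not broken down here. In a functional assay on NPC-TW01 cells (Homo sapiens) for inhibition, read by MTT assay, with a stated time of 72 h (on this read-out lower numbers stand for stronger inhibition of growth and higher numbers for weaker inhibition of growth), compound 1 gives 9300 nM. In this assay compound 2 gives 7200 nM, a number within the scatter of compound 1, so no order between the two is claimed.

Compound 3 `CN(C)/C=N/c1cc(-c2ccccc2)nn1-c1ccccc1` is compound 1 with hydrogen in place of formyl on an aromatic carbon. For compound 3 this assay returns only a limit, > 100000 nM, not a number. The step of an at least 10-fold higher number from compound 1 to compound 3 (1.03 log units; beyond the scatter) is therefore known only as a lower bound, which rests on (the limit of > 100000 nM in this assay, at which 1 of the 3 values shown sits).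

Compound 4 `Cc1ccc(-c2cc(/N=C/N(C)C)n(-c3cccc(Cl)c3)n2)cc1` is not yet measured. It is compound 2 with hydrogen in place of formyl on an aromatic carbon. This is the same kind of change as that from compound 1 to compound 3, though the surroundings differ: in compound 2 the carbon sits next to the ring atom that bears a 4-methylphenyl group and two ring bonds from the ring atom that bears a 3-chlorophenyl group, whereas in compound 1 both of those ring atoms bear a phenyl group.

Among the measured compounds shown here, since the one measured instance of this change gave an at least 10-fold higher number from compound 1 to compound 3 (1.03 log units; beyond the scatter), the same kind of step is expected for compound 4, a 14-fold higher number from compound 2 to compound 4 (1.14 log units; beyond the scatter). Compound 4 is accordingly estimated at 100000 nM, between 40000 nM and 300000 nM, with a real chance that this assay again reports only a limit.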

Compound 4, concentration for 50% growth inhibition: > 100000 nM
Compound 4 ended at the assay's limit; the forecaster's own chance of this, stated with the estimate: 60%; the middle value lies on the limit itself.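

In this assay compound 4 gives > 100000 nM, which is a limit of the assay and not a number. Hydrogen in place of formyl on the aromatic carbon of the five-membered ring thus gives an at least 13-fold higher number from compound 2 to compound 4 (1.14 log units; beyond the scatter), so the large loss of growth inhibition seen on the core of compound 1 recurs in the same direction on a core carrying a 4-methylphenyl group and a 3-chlorophenyl group: the same change on two cores in this assay, an at least 10-fold higher number (1.03 log units; beyond the scatter) from compound 1 to compound 3 and an at least 13-fold higher number (1.14 log units; beyond the scatter) from compound 2 to compound 4; the limit leaves it open whether they differ The true size of neither step can be given, and the result rests on two cores only, so it shows that the change carried over here but not that the two steps are equal, nor that it would carry over to other cores: the limit of > 100000 nM in this assay, at which 2 of the 4 values shown sit.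

The compounds shown leave open whether formyl is the only group on that aromatic carbon that keeps growth inhibition in the range of compound 1 and compound 2, or whether a nitrile, a carboxylic acid or a hydroxymethyl group would do the same. They also leave open what happens to the formyl compounds when a simple primary amine stands on the ring atom that bears the group of 5 heavy atoms.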